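The source may hold more compounds than are shown below. What is called first, only, known or untested is meant among the compounds shown, and "the series" means these compounds.

Compound 1 `CNC(=O)c1nc(-c2cccs2)[nH]c(=O)c1O` is a small amide built on a shared core. In an assay on isolated protein for inhibition of Flap endonuclease 1 (Homo sapiens) (on this read-out lower numbers stand for stronger inhibition and higher numbers for weaker inhibition), compound 1 gives 12000 nM. Two companions vary the amide end: compound 2 `O=C(c1nc(-c2cccs2)[nH]c(=O)c1O)N1CCCC1` gives 13700 nM in this assay, and compound 3 `O=C(Nc1ccc(F)cc1)c1nc(-c2cccs2)[nH]c(=O)c1O` gives 10500 nM. Compound 1 thus sits among the three with both neighbouring steps inside the scatter, as a 1.1-fold higher number from compound 1 to compound 2 (0.06 log units; within the scatter) shows. Compound 4 `O=C(Nc1cccnc1)c1nc(-c2cccs2)[nH]c(=O)c1O` carries the change (pyridin-3-yl in place of methyl on an amide-type nitrogen). Among the compounds with values here, the step that bears on it is the one toward compound 3, where a ring likewise replaced methyl on that nitrogen; because a 1.1-fold lower number from compound 1 to compound 3 (0.06 log units; within the scatter) stays within the scatter, no step beyond the scatter is expected in this assay in either direction. Compound 4 is therefore estimated at 11000 nM, within a range from 5000 nM to 25000 nM, which means an expected step of a 1.1-fold lower number from compound 1 to compound 4 (0.04 log units; within the scatter).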

Compound 4, half-maximal inhibitory concentration: 8600 nM
Compound 4: middle estimate off by 1.3-fold (0.11 log units), on the high side; measured number inside the range.
By their numbers in this assay, from the lowest: compounds 4, 3, 1 and 2 (each within the scatter of the next).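

Pyridin-3-yl, a ring that brings a nitrogen atom to this amide-type nitrogen, produces no step beyond the scatter in this assay, whether it replaces methyl (a 1.4-fold lower number from compound 1 to compound 4 (0.14 log units; within the scatter)) or 4-fluorophenyl (a 1.2-fold lower number from compound 3 to compound 4 (0.09 log units; within the scatter)), and the same holds where (pyridin-3-yl)amino replaces pyrrolidin-1-yl on the carbonyl carbon (a 1.6-fold lower number from compound 2 to compound 4 (0.20 log units; within the scatter)). A ring nitrogen at this place therefore does not set compound 4 apart from the other three compounds. No measurement at hand offers an explanation for this flat picture. From the compounds shown here alone, whether a longer chain or a carboxylic acid on this nitrogen would move the number beyond the scatter stays open.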